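Hydroxymethyl removal on the pendant phenyl of compound 2

The compounds below may be only part of what the source reports. "The series", "measured", "known", "first", "only" and "open" are said of these compounds alone.

Measured so far:
compound 1 `Cn1ncc2c(=O)n(-c3ccccc3)c(COc3cccc(F)c3)nc21`; in an assay on isolated protein for inhibition of retinal dehydrogenase 2 (Homo sapiens) (on this read-out lower numbers stand for stronger inhibition and higher numbers for weaker inhibition), compound 1 gives 1770 nM
compound 2 `CC(Sc1nc2c(cnn2C)c(=O)n1-c1ccc(CO)cc1)c1ccccc1`; in this assay compound 2 gives 600 nM

Of the two numbers in this assay, compound 2 holds the lower one; compound 1 gives a higher number, and that gap lies beyond the scatter. Compound 1 and compound 2 differ at more than one place, so no single step can be read from them. Compound 3 `CC(Sc1nc2c(cnn2C)c(=O)n1-c1ccccc1)c1ccccc1` keeps the core of compound 2 and differs from it only by hydrogen in place of hydroxymethyl on an aromatic carbon. Among the compounds with values here, no measured pair covers this change. The step from compound 2 to compound 3 in this assay is expected to be small, a 1.5-fold higher number from compound 2 to compound 3 (0.18 log units; within the scatter), probably not beyond the scatter. For compound 3 the estimated value in this assay is 900 nM, ranging from 300 nM to 2700 nM.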

Compound 3, half-maximal inhibitory concentration: 110 nM
Beside the measured number, compound 3's estimate is 8.2-fold (0.91 log units) above it, and the stated range ends above it.
By their numbers in this assay, from the lowest: compound 3; then compound 2; then compound 1.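

In this assay, within the data shown here, the change from 4-(hydroxymethyl)phenyl to phenyl gives a 5.5-fold lower number from compound 2 to compound 3 (0.74 log units; beyond the scatter) and is the first single-place step that can be read. At this position, para to a large group, hydroxymethyl is not required for inhibition, and the plain phenyl gives the lower number. Nothing available accounts for the size of this step.

On these data alone, whether an amine, a carboxylic acid or a longer chain at this position would also give a lower or a higher number remains open. As far as these compounds go, the step rests on one pair, so its behaviour with other substituents on the shared core is unknown.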